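The source may hold more compounds than are shown below. What is called first, only, known or untested is meant among the compounds shown, and "the series" means these compounds.

Compound 3 `O=C(O)C[C@H](O)C[C@H](O)CCn1c(C(F)(F)F)nc(-c2ccc(F)cc2)c1-c1ccc(C(F)(F)F)cc1` carries a 4-(trifluoromethyl)phenyl group on the core it shares with compound 1 `O=C(O)C[C@H](O)C[C@H](O)CCn1c(C(F)(F)F)nc(-c2ccc(F)cc2)c1-c1ccc(F)cc1` and compound 2 `Cc1ccc(-c2c(-c3ccc(F)cc3)nc(C(F)(F)F)n2CC[C@@H](O)C[C@@H](O)CC(=O)O)cc1`. In an assay on microsomes from liver for inhibition of 3-hydroxy-3-methylglutaryl-coenzyme A reductase (Rattus norvegicus) (on this read-out lower numbers stand for stronger inhibition and higher numbers for weaker inhibition), compound 1 gives 38 nM, and compound 2 gives 750 nM. For compound 3 this assay returns only a limit, > 1000 nM. Compound 3 is thus known only as a limit, at the limit of > 1000 nM in this assay, at which 1 of the 3 values shown sits, and no number is available for it.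

Compound 4 `Cc1cc(-c2c(-c3ccc(F)cc3)nc(C(F)(F)F)n2CC[C@@H](O)C[C@@H](O)CC(=O)O)cc(C)c1F` differs from compound 3 in one place: 4-fluoro-3,5-dimethylphenyl in place of 4-(trifluoromethyl)phenyl on an aromatic carbon. For the measured compounds named here, three measured steps bear on this change. an at least 26-fold higher number from compound 1 to compound 3 (1.42 log units; beyond the scatter) and a 20-fold higher number from compound 1 to compound 2 (1.30 log units; beyond the scatter) are both large losses when the fluoro is exchanged for trifluoromethyl or methyl; an at least 1.3-fold higher number from compound 2 to compound 3 (0.12 log units; that floor lies within the scatter) is only a floor that lies within the scatter. Compound 4 brings back a fluoro group, as in compound 1, but also carries two methyl groups on the same ring, a combination not present among the measured compounds. Going by the values given here, a move back toward the number of compound 1 is therefore expected, though a partial one, since the methyl groups have no direct precedent here.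

For compound 4 in this assay a value of 250 nM is estimated, between 50 nM and 1500 nM, which means an expected step of an at least 4.0-fold lower number from compound 3 to compound 4 (0.60 log units; beyond the scatter).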

Compound 4, half-maximal inhibitory concentration: 31 nM
Compound 4: middle estimate off by 8.1-fold (0.91 log units), on the high side, and the stated range ends above it.
By their numbers in this assay, from the lowest: compounds 4 and 1 (each within the scatter of the next); then compound 2. At a limit, above all of these: compound 3.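

In this assay, the step from 4-fluorophenyl to 4-fluoro-3,5-dimethylphenyl is a 1.2-fold lower number from compound 1 to compound 4 (0.09 log units; within the scatter), so this position accepts two added methyl groups on the aryl ring when the fluoro stays in place. Against the 4-methylphenyl group the change is a 24-fold lower number from compound 2 to compound 4 (1.38 log units; beyond the scatter), so the loss in compound 2 does not extend to every methyl-bearing ring here: it appears with methyl in place of the fluoro and is absent in compound 4, where methyl groups and fluoro occur together. Compound 3 is known only as a limit, which makes an at least 32-fold lower number from compound 3 to compound 4 (1.50 log units; beyond the scatter) a floor whose true size stays open: the limit of > 1000 nM in this assay, at which 1 of the 4 values shown sits.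

Still open, going by these compounds, is whether one methyl group with the fluoro kept, as in 4-fluoro-3-methylphenyl, behaves like the two methyl groups of compound 4, and whether the fluoro is needed at all in a 3,5-dimethylphenyl group. Also open, on these data alone, is whether a chloro or methoxy group in place of that fluoro, or the same methyl groups on the other 4-fluorophenyl group, would keep inhibition at this level.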